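The source may hold more compounds than are shown below. What is called first, only, known or untested is meant among the compounds shown, and "the series" means these compounds.

Measured compounds:
Compound 1 `Cc1cc(NC(=O)Nc2ccccc2C(F)(F)F)c2ccccc2n1` gives 3800 nM in a physicochemical assay for solubility, at pH 7.4; a lower number here means a less soluble compound, a higher number a more soluble compound.
Compound 2 `CC(=O)c1ccc(NC(=O)Nc2cc(C)nc3ccccc23)cc1` gives 3800 nM in this assay.
Compound 3 `Cc1cc(NC(=O)Nc2ccccc2OC(F)(F)F)c2ccccc2n1` gives 4600 nM in this assay.

Among these three, compound 2 stands level with compound 1 at the digits printed, and the two together give the lowest numbers of the set. Compound 3 gives a number that is higher by only a small margin, as a 1.2-fold higher number from compound 1 to compound 3 (0.08 log units; within the scatter) shows, a difference that lies within the scatter of repeated measurements.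

Compound 4 `Cc1cc(NC(=O)Nc2ccc(OC(F)(F)F)cc2)c2ccccc2n1` has not yet been measured. It differs from compound 2 in one place: trifluoromethoxy in place of acetyl on an aromatic carbon The new group sits on an aromatic carbon of a six-membered aromatic ring of carbon only, para to a large group.

Among the compounds with values here, the only measured step that bears on this change is the one from compound 1 to compound 3, in which the same trifluoromethoxy group entered, though in place of trifluoromethyl rather than acetyl; that step was small, a 1.2-fold higher number from compound 1 to compound 3 (0.08 log units; within the scatter), and within the scatter. Within the data shown here, no measured pair shows acetyl leaving, so its part in the change is not covered by the numbers. Compound 4 is therefore expected to stay close to compound 2, with a step of a 1.1-fold lower number from compound 2 to compound 4 (0.04 log units; within the scatter). The estimate for compound 4 in this assay is 3500 nM, with a range from 1800 nM to 7000 nM.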

Compound 4, solubility: 300 nM
The estimate for compound 4 lay 12-fold (1.07 log units) above the measured number, outside the stated range (below it).
By their numbers in this assay, from the lowest: compound 4; then compounds 1, 2 and 3 (each within the scatter of the next).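

In this assay, the step of a 13-fold lower number from compound 2 to compound 4 (1.10 log units; beyond the scatter) is large, so trifluoromethoxy in place of acetyl at this place, on an aromatic carbon para to a large group, is far from a neutral exchange. The same group entering in place of trifluoromethyl, in the step of a 1.2-fold higher number from compound 1 to compound 3 (0.08 log units; within the scatter) on the shared core, had given no sign of this, so that small step does not carry over to a change with a different leaving group at a different place. Compound 3 carries trifluoromethoxy elsewhere on its ring and gives 4600 nM in this set, while compound 4 gives 300 nM here, so among these two compounds the presence of the group does not by itself fix the number.

Still open, as far as these compounds go, is whether acetyl leaving or trifluoromethoxy entering carries the step, and whether another group at this place, such as an amine, a carboxylic acid or a nitrile, would stay level with compound 2 or fall towards compound 4. Nothing measured among these compounds gives a reason for the large step.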